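This account rests on a few compounds, and the source may have more. Where it says the series, first, only, none or still open, it means among the compounds named here.

Measured so far:
- compound 1, `Cn1cnnc1SCC(=O)N/N=c1/scc(-c2ccc(C#N)cc2)n1-c1ccccc1`: 153 ug/mL
- compound 2, `Cn1cnnc1SCC(=O)N/N=c1/scc(-c2ccccc2)n1-c1ccccc1`: 217 ug/mL

Both values come from an ADME assay on NIH3T3 cells (Mus musculus) for cytotoxicity, read by MTT assay, with a stated time of 24 h; a higher number here means a weaker inhibitor, a lower number a stronger inhibitor. Among the measured compounds shown here, on these two numbers compound 2 stands highest, but its only neighbour is compound 1, and the step of a 1.4-fold higher number from compound 1 to compound 2 (0.15 log units; within the scatter) lies within the scatter, so nothing separates the two in this assay; they read as one level.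

Compound 3, `COc1ccc(-c2cs/c(=N/NC(=O)CSc3nncn3C)n2-c2ccccc2)cc1`, is not yet measured. Its difference from compound 2 is methoxy in place of hydrogen on an aromatic carbon; cut one bond further out, the change reads phenyl to 4-methoxyphenyl.

For the measured compounds named here, only one measured step bears on this: the step of a 1.4-fold higher number from compound 1 to compound 2 (0.15 log units; within the scatter), which swaps a cyano for a hydrogen on the same aromatic carbon and stays within the scatter. Going by the values given here, that is the sole guide, and it concerns a different group than the methoxy entering here. Among the compounds with values here, with one small step as the only precedent, no shift beyond the scatter is expected in this assay in either direction.

Compound 3 is therefore estimated at 200 ug/mL, with a range from 100 ug/mL to 400 ug/mL, an expected step of a 1.1-fold lower number from compound 2 to compound 3 (0.04 log units; within the scatter).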

Compound 3, half-maximal inhibitory concentration: 167 ug/mL
Estimate against measurement, compound 3: 1.2-fold (0.08 log units) above; low and high end bracket the measured number.
By their numbers in this assay, from the lowest: compounds 1, 3 and 2 (each within the scatter of the next).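

Compound 2 carries only hydrogen at this place, and compound 1 adds the cyano group, so until now the position had been probed with one substituent. Methoxy is a second, different group at the same aromatic carbon, para to a large group, and it brings an oxygen that the hydrogen of compound 2 does not have. Yet in this assay the change from phenyl to 4-methoxyphenyl gives a 1.3-fold lower number from compound 2 to compound 3 (0.11 log units; within the scatter), and methoxy in place of cyano gives a 1.1-fold higher number from compound 1 to compound 3 (0.04 log units; within the scatter), so hydrogen, cyano and methoxy at this place all read as one level, and the flat reading now holds across three groups instead of two. Nothing measured on these compounds offers an explanation for this flat reading.

Three groups at one place cannot show whether this level would hold for something quite different there, such as an amine, a carboxylic acid or a longer chain. The compounds shown also leave open whether a change elsewhere on the shared core would move the number beyond the scatter.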